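The source may report more compounds than this note shows. Statements on the series, on what has been measured and on what is new or still open speak of the compounds shown alone.

Working notes on the series, read in a functional assay on the whole organism (arterial blood) with Rattus norvegicus as the target; on this read-out higher numbers stand for an effect only at larger amounts of compound and lower numbers for an effect already at smaller amounts. Compound 2 `COC(=O)NC(CC(=O)N1CCC(Cn2c(C)nc3cnccc32)CC1)c1ccccc1` gives 0.035 mg/kg and compound 1 `Cc1nc2cnccc2n1CC1CCN(C(=O)CNC(c2ccccc2)c2ccccc2)CC1` gives 0.067 mg/kg, two values within the scatter of each other. At a higher number, beyond the scatter from compound 2, compound 3 `Cc1nc2cnccc2n1C1CCN(C(=O)CC(c2ccccc2)c2ccccc2)CC1` gives 0.41 mg/kg.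

Compound 4 `CCCC(CC(=O)N1CCC(Cn2c(C)nc3cnccc32)CC1)c1ccccc1` departs from compound 2 by one change, propyl in place of (methoxycarbonyl)amino on a saturated chain carbon bound to an aromatic carbon and a saturated chain carbon. Going by the values given here, no measured pair isolates this change, so the expectation rests on indirect evidence. Two measured compounds lack the (methoxycarbonyl)amino group, but both also differ from compound 2 elsewhere: compound 1 gives 0.067 mg/kg and compound 3 gives 0.41 mg/kg. That spread leaves room for a small or a clear loss, and neither value points to a lower number than that of compound 2. The expected step in this assay is a modest one toward a higher number, estimated as a 2.9-fold higher number from compound 2 to compound 4 (0.46 log units; beyond the scatter). For compound 4 the estimate is 0.1 mg/kg, with an expected range of 0.03 mg/kg to 0.35 mg/kg.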

Compound 4, dose for 50% inhibition: 0.0079 mg/kg
Compound 4: the middle estimate sits 13-fold (1.10 log units) above what was measured, and the stated range ends above it.
By their numbers in this assay, from the lowest: compound 4; then compounds 2 and 1 (each within the scatter of the next); then compound 3.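

In this assay the swap of (methoxycarbonyl)amino for propyl on a saturated chain carbon bound to an aromatic carbon and a saturated chain carbon gives a 4.4-fold lower number from compound 2 to compound 4 (0.65 log units; beyond the scatter) and so moves the number down, beyond the scatter, not up. This pair shows that a low number at this position does not depend on (methoxycarbonyl)amino, and propyl, with no hydrogen-bond donor or acceptor, does better here. No measurement at hand gives a reason for this step.

A single pair does not separate what propyl adds from what the loss of (methoxycarbonyl)amino removes. From the compounds shown here alone, how the number moves with a shorter chain such as methyl, a longer chain such as butyl, or an amine on this saturated chain carbon stays open.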